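Nitro for cyano on the aryl ring of the dienone

A few compounds are considered here, and "the series" means these few. Any claim that something is new, unique, unknown or untested is made for them only; others in the source may bear on it.

The two measured compounds share one core and differ only in the substituent on the aromatic ring. Compound 1 `CC1=C(/C=C/C(=O)/C=C/c2cccc(C(F)(F)F)c2)C(C)(C)CCC1O` gives 740 nM in a functional assay on LNCaP cells (Homo sapiens) for cytotoxicity, read by MTT assay, with a stated time of 72 h; on this read-out higher numbers stand for weaker inhibition and lower numbers for stronger inhibition. Compound 2 `CC1=C(/C=C/C(=O)/C=C/c2cccc(C#N)c2)C(C)(C)CCC1O` gives 1800 nM in this assay. Going by the values given here, the step of a 2.4-fold higher number from compound 1 to compound 2 (0.39 log units; beyond the scatter) is the only one measured so far; it leaves compound 2 with the higher of the two numbers, and compound 1 is its only neighbour.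

Compound 3 `CC1=C(/C=C/C(=O)/C=C/c2cccc([N+](=O)[O-])c2)C(C)(C)CCC1O` carries the next change at the same position: nitro in place of cyano on an aromatic carbon. Among the compounds with values here, no measured step replaces cyano with nitro anywhere, so the one step that bears on this change is the earlier exchange on the same carbon, a 2.4-fold higher number from compound 1 to compound 2 (0.39 log units; beyond the scatter), which was modest. A step of at most that order is therefore expected for compound 3, in either direction, with no clear reason to favour one; the estimated step from compound 2 is a 1.2-fold lower number from compound 2 to compound 3 (0.08 log units; within the scatter). Compound 3 is expected to give about 1500 nM in this assay, within a range of 600 nM to 4000 nM.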

Compound 3, half-maximal inhibitory concentration: 2000 nM
For compound 3 the middle estimate is 1.3-fold (0.12 log units) below the measured one; the measured number falls inside the stated range.
By their numbers in this assay, from the lowest: compound 1; then compounds 2 and 3 (each within the scatter of the next).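

In (this assay), nitrile and nitro on this aromatic carbon cannot be told apart (step: a 1.1-fold higher number from compound 2 to compound 3 (0.05 log units; within the scatter)), although the two groups differ in heavy atoms and in hydrogen-bond acceptors. Trifluoromethyl now stands apart from two replacements instead of one: the exchange for nitro (step: a 2.7-fold higher number from compound 1 to compound 3 (0.43 log units; beyond the scatter)) is modest and beyond the scatter, as is the exchange for nitrile (step: a 2.4-fold higher number from compound 1 to compound 2 (0.39 log units; beyond the scatter)), so compound 1 holds the lowest number of the three and the position shows a difference only between trifluoromethyl and the other two groups. No measurement on these compounds accounts for that difference.

As far as these compounds go, whether trifluoromethyl is alone in giving the lower number remains open, and an amine, a carboxylic acid or a methoxy group on the same aromatic carbon would show whether the numbers spread further or stay close to those of compound 2 and compound 3. From the compounds shown here alone, it is also open whether the same separation holds when the group sits on another carbon of the aromatic ring, since all three compounds carry it at one place.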